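A few compounds are considered here, and "the series" means these few. Any claim that something is new, unique, unknown or untested is made for them only; others in the source may bear on it.

Compounds measured so far in an assay on HEK293 cells for displacement of a labelled ligand from NPC1-like intracellular cholesterol transporter 1 (Homo sapiens); on this read-out lower numbers stand for stronger inhibition and higher numbers for weaker inhibition:
compound 1 `CC(C)(C)OC(=O)NCCCNC(=O)CN1CN(c2ccccc2)C2(CCN(C(=O)c3ccc(C4CCCCC4)cc3)CC2)C1=O`: 6000 nM
compound 2 `CC(C)(C)OC(=O)NCCCNC(=O)CN1CN(c2ccccc2)C2(CCN(C(=O)c3ccc(C(C)(C)C)cc3)CC2)C1=O`: 4500 nM
compound 3 `CC(C)(C)OC(=O)NCC1CCCN(C(=O)CN2CN(c3ccccc3)C3(CCN(C(=O)c4ccc(C(C)(C)C)cc4)CC3)C2=O)C1`: 9500 nM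

Compound 2 gives the lowest number of the three, though compound 1 lies within the scatter of it; only compound 3 stands beyond the scatter, with the higher number. Compound 4 `CCOC(=O)C1CCN(C(=O)CN2CN(c3ccccc3)C3(CCN(C(=O)c4ccc(C(C)(C)C)cc4)CC3)C2=O)CC1` is not yet measured. It differs from compound 2 by 4-(ethoxycarbonyl)piperidin-1-yl in place of (3-((tert-butoxycarbonyl)amino)propyl)amino on a carbonyl carbon. Within the data shown here, the one computed step, a 1.3-fold lower number from compound 1 to compound 2 (0.12 log units; within the scatter), concerns the aromatic substituent rather than the amide side, so it bears little on this change. Compound 2 and compound 3 share the aryl group and differ only on that amide side, and compound 3 gives the higher number, beyond the scatter. The change to compound 4 likewise moves from an open-chain amide to a ring-bound one, so a step of a 1.7-fold higher number from compound 2 to compound 4 (0.22 log units; within the scatter) toward a higher number is expected, though the ring of compound 4 differs from that of compound 3 and the size is uncertain. Compound 4 is estimated at 7500 nM, with a range of 3000 nM to 18000 nM.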

Compound 4, half-maximal inhibitory concentration: 3100 nM
Beside the measured number, compound 4's estimate is 2.4-fold (0.38 log units) above it; measured number inside the range.
By their numbers in this assay, from the lowest: compounds 4, 2, 1 and 3 (each within the scatter of the next, the first and the last beyond it).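

On the carbonyl carbon, 4-(ethoxycarbonyl)piperidin-1-yl replaces (3-((tert-butoxycarbonyl)amino)propyl)amino with a 1.5-fold lower number from compound 2 to compound 4 (0.16 log units; within the scatter), so this position tolerates a ring-bound amide without hydrogen-bond donors in the entering group. A ring on this amide side does not by itself go with the higher number: in this assay compound 3 gives 9500 nM and compound 4 gives 3100 nM. Nothing available explains this result.

Still open, as far as these compounds go, is whether a carboxylic acid or a primary amine in place of the ethoxycarbonyl group would hold the number. Also open, from the compounds shown here alone, is whether the same swap behaves alike with cyclohexyl on the aromatic carbon.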